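A few compounds are considered here, and "the series" means these few. Any claim that something is new, unique, unknown or untested is made for them only; others in the source may bear on it.

Measured so far:
compound 1 `CCc1ccc(S(=O)(=O)N2CCC(N3CCC(C)CC3)CC2)cc1`: > 5000 nM
compound 2 `CC1CCN(C2CCN(S(=O)(=O)c3ccccc3-c3ccc(C(F)(F)F)cc3)CC2)CC1`: > 5000 nM

Compound 2 sits only at a limit in an ADME assay on HCT-116 cells (Homo sapiens) for cytotoxicity, read by CellTiter-Glo, with a stated time of 72 h (a lower number here means a stronger inhibitor, a higher number a weaker inhibitor), and gives no number. Compound 1 likewise sits at a limit in this assay. Both values shown stand at the limit of > 5000 nM in this assay, at which 2 of the 2 values shown sit, so neither a step nor an order between compound 1 and compound 2 can be read.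

Compound 3 `CC1CCN(C2CCN(S(=O)(=O)c3ccccc3-c3ccc(Cl)cc3)CC2)CC1` differs from compound 2 by chloro in place of trifluoromethyl on an aromatic carbon. For the measured compounds named here, no measured step of this kind is available. The expected step that the limit leaves unreadable from compound 2 to compound 3 is small and within the scatter, since compound 2 gives > 5000 nM. Compound 3 is estimated at 8000 nM, ranging from 3000 nM to 30000 nM.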

Compound 3, half-maximal inhibitory concentration: > 5000 nM
Compound 3 was reported as a limit (the forecaster's own chance of this, stated with the estimate: 75%); the middle value is on the limit's open side.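

In this assay no new step can be read between compound 2 and compound 3, as both values are limits: the limit of > 5000 nM in this assay, at which 3 of the 3 values shown sit. The compounds shown leave open how chloro and trifluoromethyl compare here, and whether any of these compounds has a measurable value.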